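Exchanging the Amine Chain of Compound 1

This account rests on a few compounds, and the source may have more. Where it says the series, first, only, none or still open, it means among the compounds named here.

In a functional assay on HCT-116 cells (Homo sapiens) for antiproliferative activity, read by MTT assay, with a stated time of 48 h (on this read-out higher numbers stand for weaker inhibition and lower numbers for stronger inhibition), compound 1 `COc1ccc(/C=C/C(=O)c2cc(OC)c(OC)c(OC)c2)cc1OCCCC(=O)NCCCNCCCCNCCN` gives 55800 nM, and compound 2 `COc1cc(C(=O)/C=C/c2ccc(OCCCC(=O)NCCCNCCCCNCCN)cc2)cc(OC)c1OC` gives 33800 nM. Going by the values given here, these two values lie within the scatter of each other, so compound 1 stands level with the only other compound measured so far. The two differ in the core and carry the same amine chain.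

Compound 3 `COc1ccc(/C=C/C(=O)c2cc(OC)c(OC)c(OC)c2)cc1OCCCC(=O)NCCCCNCCCN` keeps the core of compound 1 and alters only that chain: ((3-aminopropyl)amino)methyl in place of (4-((2-aminoethyl)amino)butyl)amino on a saturated chain carbon, three bonds along the chain from an amide-type nitrogen. In words, ((3-aminopropyl)amino)methyl stands in place of (4-((2-aminoethyl)amino)butyl)amino on a saturated chain carbon, three bonds along the chain from an amide-type nitrogen.

Among the compounds with values here, no measured pair isolates this exchange, so the data offer no direct guide to its size. The expectation therefore starts from compound 1 at 55800 nM, and no step beyond the scatter is expected in this assay, in either direction. The estimated change is a 1.2-fold lower number from compound 1 to compound 3 (0.09 log units; within the scatter), which stays within the scatter. Compound 3 is estimated at 45000 nM, with an expected range of 16000 nM to 100000 nM.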

Compound 3, half-maximal inhibitory concentration in the HCT-116 assay: 38000 nM
Estimate against measurement, compound 3: 1.2-fold (0.07 log units) above; low and high end bracket the measured number.
By their numbers in the HCT-116 assay, from the lowest: compounds 2, 3 and 1 (each within the scatter of the next).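

The first direct test of this position shows that the amine chain can be exchanged on the core of compound 1 without a step beyond the scatter: in the HCT-116 assay, compound 1 gives 55800 nM and compound 3 gives 38000 nM, and ((3-aminopropyl)amino)methyl in place of (4-((2-aminoethyl)amino)butyl)amino, which takes the group from 9 heavy atoms to 6 heavy atoms, gives a 1.5-fold lower number from compound 1 to compound 3 (0.17 log units; within the scatter). In a physicochemical assay for lipophilicity, read by spectrophotometry, measured as octanol-water partition, tested at 300 uM (a higher number here means a more lipophilic compound, a lower number a more polar compound), compound 1 gives -1.57 and compound 3 gives -1.28, and the same exchange gives a number 0.29 log units higher from compound 1 to compound 3 (within the scatter), so neither read-out separates the two chains, and both compounds stand level in each. Nothing available explains why these two chains read alike.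

The compounds shown leave open whether the level holds for a chain cut back to a single terminal primary amine, for a longer polyamine chain, or for a chain ending in a carboxylic acid on a saturated chain carbon at this position. They also leave open whether ((3-aminopropyl)amino)methyl reads the same on the core of compound 2, which so far carries only the longer chain.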